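Replacing 4-fluorophenyl with furan-2-yl in compound 3

The compounds below may be only part of what the source reports. "The series", "measured", "known", "first", "only" and "open" are said of these compounds alone.

Of the compounds shown here, three that share one core have been measured in a functional assay on MCF7 cells (Homo sapiens) for inhibition, read by CCK-8 assay, with a stated time of 48 h (on this read-out lower numbers stand for stronger inhibition of growth and higher numbers for weaker inhibition of growth), so far. Compound 1 `Cc1ccccc1Nc1nc(Nc2ccc(N3CCN(C)CC3)cn2)ncc1Cl` gives 5210 nM and compound 2 `Cc1ccc(CNc2nc(Nc3ccc(N4CCN(C)CC4)cn3)ncc2Cl)cc1` gives 38100 nM while compound 3 `CN1CCN(c2ccc(Nc3ncc(Cl)c(NCc4ccc(F)cc4)n3)nc2)CC1` gives 19300 nM as its number. Compound 3 therefore lies within the scatter of compound 2 and shows weaker growth inhibition than compound 1.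

The next compound, compound 4 `CN1CCN(c2ccc(Nc3ncc(Cl)c(NCc4ccco4)n3)nc2)CC1`, has furan-2-yl in place of 4-fluorophenyl on a saturated chain carbon bound to a nitrogen on an aromatic ring and is otherwise unchanged. Among the measured compounds shown here, no measured compound carries a furan-2-yl group, so the evidence is indirect.

The closest guide is a 2.0-fold lower number from compound 2 to compound 3 (0.30 log units; within the scatter) for fluoro in place of methyl on an aromatic carbon. The modest steps of a 7.3-fold higher number from compound 1 to compound 2 (0.86 log units; beyond the scatter) and a 3.7-fold higher number from compound 1 to compound 3 (0.57 log units; beyond the scatter) both replace 2-methylphenyl on the nitrogen with a benzyl group, and compound 4 keeps the chain carbon of the benzyl compounds. A step beyond the scatter is therefore not expected in this assay here. On these data alone, the expected change is a 1.0-fold higher number from compound 3 to compound 4 (0.02 log units; within the scatter) and its direction remains open. For compound 4 the estimate is 20000 nM with 8000 nM to 50000 nM as the expected range.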

Compound 4, concentration for 50% growth inhibition: 21300 nM
The estimate for compound 4 lay 1.1-fold (0.03 log units) below the measured number; measured number inside the range.
By their numbers in this assay, from the lowest: compound 1; then compounds 3, 4 and 2 (each within the scatter of the next).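

In this assay the change from 4-fluorophenyl to furan-2-yl gives a 1.1-fold higher number from compound 3 to compound 4 (0.04 log units; within the scatter) and so stays inside the scatter, which shows that this place on the saturated chain carbon accepts a smaller, five-membered aromatic ring with an oxygen in it without a readable shift. Set against the 4-methylphenyl group, the furan-2-yl gives a 1.8-fold lower number from compound 2 to compound 4 (0.25 log units; within the scatter) and is again inside the scatter, so the three rings carried on this chain carbon cannot be told apart, while a 4.1-fold higher number from compound 1 to compound 4 (0.61 log units; beyond the scatter) places (furan-2-yl)methyl with the two benzyl groups, all beyond the scatter from the 2-methylphenyl of compound 1. No supporting measurement is available to explain why these rings read alike. 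

On these data alone, all three rings tried on the chain carbon are aromatic, so it remains open whether a saturated ring such as cyclohexyl, or a basic group such as a dimethylamino group, would read differently here. A longer chain, such as a two-carbon link from the nitrogen to the ring, is also untested among the compounds shown, and so is whether it would bring the number closer to that of compound 1.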